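This account rests on a few compounds, and the source may have more. Where it says the series, first, only, none or still open, it means among the compounds named here.

Measured in a physicochemical assay for lipophilicity, read by HPLC, measured as chromatographic lipophilicity, at pH 7.4; on this read-out higher numbers stand for higher lipophilicity and lower numbers for lower lipophilicity:
compound 1 `O=C(C1CCN(c2ccncn2)CC1)N1N=CC[C@H]1c1ccccc1` — 3.2
compound 2 `CC(C)(C)C(=O)N1N=CCC1c1cocn1` — 3
compound 3 `CC(C)(C)C(=O)N1CCSC1c1ccccc1` — 5.6

In this assay compound 1 gives 3.2, and compound 2 gives 3; the gap between these two lies within the scatter, so the two values are not told apart. Compound 3, at 5.6, sits well beyond the scatter above both. No pair of these compounds differs in a single place, so no measured step is available.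

Compound 4 `O=C(C1CCN(c2cccnn2)CC1)N1N=CC[C@H]1c1ccccc1` is not yet measured. It differs from compound 1 as follows: pyridazin-3-yl in place of pyrimidin-4-yl on an amine nitrogen in a ring. Among the compounds with values here, with no measured step to rest on, the expectation for this change is a small shift downward, likely near or just beyond the scatter. Starting from compound 1 at 3.2, compound 4 is estimated at 2.9, range 2.5 to 3.3, a step of a number 0.30 log units lower from compound 1 to compound 4 (within the scatter).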

Compound 4, distribution coefficient: 3.4
Beside the measured number, compound 4's estimate is 0.50 log units below it; measured number above the stated range.
By their numbers in this assay, from the lowest: compounds 2, 1 and 4 (each within the scatter of the next, the first and the last beyond it); then compound 3.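

Pyridazin-3-yl in place of pyrimidin-4-yl on an amine nitrogen in a ring gives, in this assay, a number 0.20 log units higher from compound 1 to compound 4 (within the scatter), the first single-place step in the series. The two groups, with the same atoms joined differently, are not told apart at this position on this read-out.

As far as these compounds go, it remains open whether a group with a carboxylic acid or an amine on that same nitrogen-bearing position would give a step beyond the scatter. Nothing available bears on why these two groups read alike.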